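The source may report more compounds than this note shows. Statements on the series, on what has been measured and on what is new or still open speak of the compounds shown alone.

Measured so far in an assay on CHO cells for displacement of a labelled ligand from D(4) dopamine receptor (Homo sapiens), read by radioligand binding; a higher number here means a weaker inhibitor, a lower number a stronger inhibitor: compound 1 `COc1ccccc1N1CCN(CCCNC(=O)NN(Cc2ccc(C#N)cc2)c2ccc(Cl)cc2Cl)CC1` gives 12 nM; compound 2 `COc1ccc(N(Cc2ccccc2)NC(=O)NCCCN2CCN(c3ccccc3OC)CC2)cc1` gives 1.7 nM; compound 3 `COc1ccc(N(Cc2ccc(F)cc2)NC(=O)NCCCN2CCN(c3ccccc3OC)CC2)cc1` gives 2.9 nM.

Compound 3 stands second highest of these three numbers. Its nearest neighbour is compound 2, the step being a 1.7-fold higher number from compound 2 to compound 3 (0.23 log units; within the scatter), within the scatter; its furthest is compound 1, whose gap lies beyond the scatter. Compound 4 `COc1ccc(N(Cc2ccc(C#N)cc2)NC(=O)NCCCN2CCN(c3ccccc3OC)CC2)cc1` differs from compound 3 by cyano in place of fluoro on an aromatic carbon. For the measured compounds named here, no measured step exchanges fluoro for cyano on the shared core. Compound 1 also carries a 4-cyanobenzyl group, but on a different core, so its value bears on compound 4 only loosely. Going by the values given here, the single step on the shared core was small. Compound 4 is therefore expected to shift by a 1.4-fold higher number from compound 3 to compound 4 (0.14 log units; within the scatter) in this assay, not clearly beyond the scatter. Compound 4 is estimated at 4 nM, with a range from 1.5 nM to 12 nM.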

Compound 4, inhibition constant: 16 nM
Compound 4: the middle estimate sits 4.0-fold (0.60 log units) below what was measured; the measured number lies above the stated range.
By their numbers in this assay, from the lowest: compounds 2 and 3 (each within the scatter of the next); then compounds 1 and 4 (each within the scatter of the next).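

In this assay the 4-benzyl substituent on the shared core matters: 4-fluorobenzyl to 4-cyanobenzyl gives a 5.5-fold higher number from compound 3 to compound 4 (0.74 log units; beyond the scatter) and cyano in place of hydrogen gives a 9.4-fold higher number from compound 2 to compound 4 (0.97 log units; beyond the scatter), whereas fluoro in place of hydrogen had stayed within the scatter. With the 4-cyanobenzyl group held, 4-methoxyphenyl in place of 2,4-dichlorophenyl on the amine nitrogen gives only a 1.3-fold higher number from compound 1 to compound 4 (0.12 log units; within the scatter). No measurement at hand accounts for the cyano step. On these data alone, whether a trifluoromethyl group or an amine in this place would read like fluoro or like cyano remains open.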